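The source may hold more compounds than are shown below. What is called first, only, known or untested is meant among the compounds shown, and "the series" means these compounds.

Measured so far in an ADME assay on HFF cells (Homo sapiens) for cytotoxicity, read by MTT assay; a higher number here means that more compound is tolerated, a lower number that less compound is tolerated:
compound 1 `Nc1cc2c(=O)c(C(=O)O)cn(C3CC3)c2cc1N1CCN(c2ccccn2)CC1`: 431000 nM
compound 2 `O=C(O)c1cn(C2CC2)c2cc(N3CCN(c4ccccn4)CC3)ccc2c1=O`: 390000 nM

For the measured compounds named here, with only these two numbers, compound 1 sits level with its sole neighbour, as a 1.1-fold lower number from compound 1 to compound 2 (0.04 log units; within the scatter) shows. Compound 3 `CCOC(=O)c1cn(C2CC2)c2cc(N3CCN(c4ccccn4)CC3)c(N)cc2c1=O` keeps the core of compound 1 and changes one group: ethyl in place of hydrogen on an oxygen next to a carbonyl group, which reads carboxy to ethoxycarbonyl. Going by the values given here, the one measured step, a 1.1-fold lower number from compound 1 to compound 2 (0.04 log units; within the scatter), is hydrogen in place of amino on an aromatic carbon. It lies elsewhere on the structure and so bears only indirectly. Among the compounds with values here, no measured step covers carboxy to ethoxycarbonyl, so the direction is a judgement, not a trend. A modest move to a lower number in this assay is expected, and the range is kept wide. The expected step is a 1.7-fold lower number from compound 1 to compound 3 (0.24 log units; within the scatter). For compound 3 the estimate is 250000 nM, with an expected range of 80000 nM to 600000 nM.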

Compound 3, half-maximal cytotoxic concentration: 409000 nM
Beside the measured number, compound 3's estimate is 1.6-fold (0.21 log units) below it; the range from low to high includes it.
By their numbers in this assay, from the lowest: compounds 2, 3 and 1 (each within the scatter of the next).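

In this assay, the hydrogen on the oxygen next to a carbonyl group gives way to ethyl with a 1.1-fold lower number from compound 1 to compound 3 (0.02 log units; within the scatter), so this first measured change at the carboxy group leaves the number within the scatter. This is a second place on the core of compound 1 where a single change stays within the scatter, after the earlier amino-to-hydrogen step (a 1.1-fold lower number from compound 1 to compound 2 (0.04 log units; within the scatter)). No available evidence explains why replacing carboxy with ethoxycarbonyl makes so little difference here.

The compounds shown leave open whether this tolerance extends beyond ethyl at the same oxygen, for example to a longer chain such as butyl, or to a benzyl group. They also leave open whether replacing the carboxy group with a primary amide would stay within the scatter of compound 1.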